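Lengthening an Amine Chain by One Carbon

The compounds below may be only part of what the source reports. "The series", "measured", "known", "first", "only" and "open" are said of these compounds alone.

In a functional assay on LNCaP cells (Homo sapiens) for antiproliferative activity, read by WST assay, with a stated time of 3 days (a lower number here means a stronger inhibitor, a higher number a weaker inhibitor), compound 1 `CCCCOc1c(-c2cc(OC)c(OC)c(OC)c2)oc2ccccc2c1=O` gives 8900 nM, and compound 2 `CCCN(CCC)CCCOc1c(-c2cc(OC)c(OC)c(OC)c2)oc2ccccc2c1=O` gives 17900 nM. Only these two compounds have been measured, and their values lie within the usual scatter of each other, so compound 2 cannot be ranked against compound 1.

Compound 3 `CCCN(CCC)CCCCOc1c(-c2cc(OC)c(OC)c(OC)c2)oc2ccccc2c1=O` differs from compound 2 by (dipropylamino)methyl in place of dipropylamino on a saturated chain carbon, three bonds along the chain from an oxygen on an aromatic ring. In plain terms, 3-(dipropylamino)propyl becomes 4-(dipropylamino)butyl. The nearest evidence is a 2.0-fold higher number from compound 1 to compound 2 (0.30 log units; within the scatter), a change of methyl to dipropylamino on the same chain. That step stays within the scatter, yet it is a different change, and no change in chain length has been measured. No shift beyond the scatter is therefore expected in this assay. The expected step is a 1.5-fold lower number from compound 2 to compound 3 (0.17 log units; within the scatter). For compound 3 the estimated value is 12000 nM, with an expected range from 4000 nM to 30000 nM.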

Compound 3, half-maximal inhibitory concentration: 16800 nM
Compound 3: middle estimate off by 1.4-fold (0.15 log units), on the low side, and the stated range covers the measured number.
By their numbers in this assay, from the lowest: compounds 1, 3 and 2 (each within the scatter of the next).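

In this assay, going from 3-(dipropylamino)propyl to 4-(dipropylamino)butyl gives a 1.1-fold lower number from compound 2 to compound 3 (0.03 log units; within the scatter) and so leaves these two chain lengths unseparated at this position. Placing dipropylamino on the end of the four-carbon chain of compound 1 gives a 1.9-fold higher number from compound 1 to compound 3 (0.28 log units; within the scatter) and thereby tests the amine with the chain length held the same, a comparison that also stays within the scatter. No supporting measurement is available to explain either result.

With so few compounds, a single extra carbon cannot be said to have no effect on other chains or amines. Still open, on these data alone, is whether a longer chain, such as 5-(dipropylamino)pentyl, or a carboxylic acid in place of the dipropylamino group, would give a step beyond the scatter.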